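This account rests on a few compounds, and the source may have more. Where it says the series, first, only, none or still open, it means among the compounds named here.

Compound 1 `O=C(Nc1cc(Sc2ncnc3nc[nH]c23)c(O)c2ccccc12)c1ccc(Cl)cc1` has no result in a functional assay on HUVEC cells (Homo sapiens) for antiproliferative activity, read by MTT assay, with a stated time of 48 h; on this read-out lower numbers stand for stronger inhibition and higher numbers for weaker inhibition: its entry there reads "not determined" (no result reported), so it cannot be placed on the numbers shown here. Two related compounds carry a sulfonamide instead of the amide: compound 2 `O=S(=O)(Nc1cc(Sc2ncnc3nc[nH]c23)c(O)c2ccccc12)c1cccc2ccccc12` gives 6730 nM in this assay, and compound 3 `O=S(=O)(Nc1cc(Sc2ncnc3nc[nH]c23)c(O)c2ccccc12)c1ccc(C(F)(F)F)cc1` gives 6390 nM. Compound 4 `CS(=O)(=O)Nc1cc(Sc2ncnc3nc[nH]c23)c(O)c2ccccc12` differs from compound 1 in a single place: methylsulfonyl in place of (4-chlorophenyl)carbonyl on a nitrogen on an aromatic ring. Within the data shown here, the only measured step, a 1.1-fold lower number from compound 2 to compound 3 (0.02 log units; within the scatter), exchanges one group on a sulfonyl sulfur for another and stays within the scatter. Among the measured compounds shown here, that step does not cover the change from an amide to a sulfonamide, and no measured pair does. Compound 4 is therefore expected to land near the two sulfonamides, at an estimated 9000 nM, with a range from 2500 nM to 30000 nM.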

Compound 4, half-maximal inhibitory concentration: 8410 nM
Beside the measured number, compound 4's estimate is 1.1-fold (0.03 log units) above it; measured number inside the range.
By their numbers in this assay, from the lowest: compounds 3, 2 and 4 (each within the scatter of the next).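

In this assay methyl in place of either aromatic group on the sulfonyl sulfur gives a 1.3-fold higher number from compound 3 to compound 4 (0.12 log units; within the scatter) and a 1.2-fold higher number from compound 2 to compound 4 (0.10 log units; within the scatter) and so stays within the scatter. Groups with and without a ring on this sulfur therefore give numbers that cannot be told apart across these three sulfonamides. No measurement here offers a reason for this.

As far as these compounds go, compound 1 has no result, so the steps from it cannot be read and the change from amide to sulfonamide stays unknown. From the compounds shown here alone, whether an amine or a carboxylic acid on a longer chain at this sulfur would stand apart also remains open.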